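This account rests on a few compounds, and the source may have more. Where it says the series, first, only, none or still open, it means among the compounds named here.

Four compounds share a common core and differ in the groups attached to it. Compound 1 `CC1CN(c2c(F)cc3c(=O)c(C(=O)O)cn(C4CC4)c3c2Cl)CC(C)N1`, compound 2 `COc1c(N2CC(C)NC(C)C2)c(F)cc2c(=O)c(C(=O)O)cn(C3CC3)c12` and compound 3 `COc1c(F)c(N2CCC(N)C2)c(Cl)c2c1c(=O)c(C(=O)O)cn2C1CC1` have been measured, while compound 4 `NC1CCN(c2c(F)c(Cl)c3c(=O)c(C(=O)O)cn(C4CC4)c3c2Cl)C1` has not.

In a functional assay on V79 cells (Cricetulus griseus) for cytotoxicity, read by colony formation (a higher number here means a weaker inhibitor, a lower number a stronger inhibitor), compound 1 gives 140 ug/mL. For compound 2 this assay reports only a limit, > 500 ug/mL. For compound 3 this assay likewise reports only a limit, > 500 ug/mL. Two of the three values therefore sit at the limit of > 500 ug/mL in this assay, at which 2 of the 3 values shown sit.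

Compound 1 differs from compound 2 in one place: chloro in place of methoxy on an aromatic carbon. That change produced an at least 3.5-fold lower number from compound 2 to compound 1 (0.55 log units; beyond the scatter).

Compound 4 differs from compound 3 in the same kind of way: chloro in place of methoxy on an aromatic carbon. The surroundings are not identical, though: in compound 1 the changed carbon is ortho to a 3,5-dimethylpiperazin-1-yl group and meta to a fluoro group, whereas in compound 4 it is ortho to a fluoro group, meta to a 3-aminopyrrolidin-1-yl group and para to a chloro group. How the core of compound 3 differs from the core of compound 2 is not broken down here.

For compound 4 a step of roughly an at least 2.7-fold lower number from compound 3 to compound 4 (0.44 log units; beyond the scatter) is expected. This expectation rests on an at least 3.5-fold lower number from compound 2 to compound 1 (0.55 log units; beyond the scatter) and on compound 1 with its value of 140 ug/mL. Since compound 3 starts from a limit, the true size of the step remains uncertain. Compound 4 is accordingly estimated at about 180 ug/mL, most likely between 60 ug/mL and 500 ug/mL.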

Compound 4, half-maximal inhibitory concentration: > 500 ug/mL
Compound 4: no number, only a limit; the forecaster's own chance of this, stated with the estimate: 35%; middle value at least 2.7-fold (0.44 log units) from the limit.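

In this assay compound 4 gives only a limit, > 500 ug/mL. Compound 3 also stands at a limit, so no step can be read between compound 3 and compound 4. The compounds shown leave open whether chloro in place of methoxy lowers the number on the core of compound 3, because both values rest on the same limit: the limit of > 500 ug/mL in this assay, at which 3 of the 4 values shown sit.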